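Sulfamate amide series: lipophilicity outlook for compound 4

The source may hold more compounds than are shown below. What is called first, only, known or untested is meant among the compounds shown, and "the series" means these compounds.

Measured compounds:
compound 1 `CN(C)CCN(CCN(C)C)c1ccc(C(=O)N2CCc3ccc(OS(N)(=O)=O)cc3C2)cc1` gives 1.93
compound 2 `NS(=O)(=O)Oc1ccc2c(c1)CN(C(=O)c1ccc(N3CCC(N4CCCCC4)CC3)cc1)CC2` gives 1.93
compound 3 `NS(=O)(=O)Oc1ccc2c(c1)CN(C(=O)c1ccc(N3CCN(c4ncccn4)CC3)cc1)CC2` gives 1.93

In a physicochemical assay for lipophilicity (a lower number here means a more polar compound, a higher number a more lipophilic compound), compound 1 stands level with compound 2 and compound 3 at the digits reported; the nearest is compound 2 and the furthest compound 3, and neither gap reaches beyond the scatter of this assay. The three share a core and differ only in the amine-bearing group on the aromatic ring, and across those three groups this assay shows no separation at all. Among the compounds with values here, no pair of measured compounds differs in a single place, so no single step is available to lean on.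

Compound 4 `CN(CCN1CCCCC1)c1ccc(C(=O)N2CCc3ccc(OS(N)(=O)=O)cc3C2)cc1` is the next member. Relative to compound 1 the change is methyl(2-(piperidin-1-yl)ethyl)amino in place of bis(2-(dimethylamino)ethyl)amino on an aromatic carbon. With one nitrogen fewer and a six-membered non-aromatic ring entering, a small shift toward the lipophilic side is expected, though one that stays within the scatter. Compound 4 is expected to give 2.1, within 1.6 to 2.6. The expected step is a number 0.17 log units higher from compound 1 to compound 4 (within the scatter).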

Compound 4, partition coefficient: 1.93
For compound 4 the middle estimate is 0.17 log units above the measured one; the measured number falls inside the stated range.
By their numbers in this assay, from the lowest: compounds 1, 2, 3 and 4 (each within the scatter of the next).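

In this assay, within the data shown here, the first step that changes a single place reads no change at the digits printed from compound 1 to compound 4 (within the scatter), with methyl(2-(piperidin-1-yl)ethyl)amino in place of bis(2-(dimethylamino)ethyl)amino on an aromatic carbon, para to a large group. Among these compounds, at this position, then, the entering group's one six-membered non-aromatic ring and one nitrogen fewer leave the read-out level at the digits printed, which the earlier compounds, with no single-place step among them, could not show. No measurement at hand offers a reason for this flat result.

Whether a carboxylic acid or a morpholine ring at this same place would separate from compound 1 remains open in the compounds shown. Also open, as far as these compounds go, is whether a longer chain between the two nitrogens of the methyl(2-(piperidin-1-yl)ethyl)amino group would leave the read-out just as level.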